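Hydroxy for Methyl on the Phenyl of Compound 2

The compounds below may be only part of what the source reports. "The series", "measured", "known", "first", "only" and "open" are said of these compounds alone.

Measured so far in a functional assay on the whole organism (strain albino) for inhibition, with Rattus norvegicus as the target, read by paw edema, with stated times of 1 h and 4 h, at a dose of 200 mg/kg by the oral route; a higher number here means more inhibition at the dose given (going by the name of the read-out), a lower number less inhibition:
compound 1, `O=c1oc2ccccc2cc1C1=NN(c2ccccc2)[C@@H](c2ccc(Cl)cc2)C1`: 64.7%
compound 2, `Cc1ccc([C@H]2CC(c3cc4ccccc4oc3=O)=NN2c2ccccc2)cc1`: 38%

Of the compounds shown here, two of a shared core have been measured. Compound 1 gives 64.7% in this assay, while compound 2 gives 38%. Going by the values given here, compound 2 therefore stands lowest of the two numbers, and its only neighbour is compound 1, which lies higher by a margin beyond the scatter. That single measured step, a number 26.7 percentage points lower from compound 1 to compound 2 (beyond the scatter), is modest in size and arises from methyl in place of chloro on an aromatic carbon.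

Compound 3 `O=c1oc2ccccc2cc1C1=NN(c2ccccc2)[C@@H](c2ccc(O)cc2)C1` is not yet measured. It differs from compound 2 in one place: hydroxy in place of methyl on an aromatic carbon. Among the compounds with values here, no measured step exchanges methyl for hydroxy, so the one known step, a number 26.7 percentage points lower from compound 1 to compound 2 (beyond the scatter), bears on it only indirectly, by showing that a single change at this aromatic carbon can shift this assay by a modest amount beyond the scatter. Without a closer parallel, the expected step from compound 2 to compound 3, a number 7 percentage points higher from compound 2 to compound 3 (within the scatter), is held small and within the scatter, with a wide range. Compound 3 is therefore estimated at 45%, expected to fall between 25% and 65%.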

Compound 3, a percentage reported as inhibition, in the whole organism at one dose (the size of the read-out at that dose, not a potency): 34.6%
Beside the measured number, compound 3's estimate is 10.4 percentage points above it; the measured number falls inside the stated range.
By their numbers in this assay, from the lowest: compounds 3 and 2 (each within the scatter of the next); then compound 1.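

In this assay, exchanging 4-methylphenyl for 4-hydroxyphenyl, which brings in a hydrogen-bond donor and acceptor that methyl does not have, gives a number 3.4 percentage points lower from compound 2 to compound 3 (within the scatter), so this assay does not tell these two groups apart at this aromatic carbon. Going by these compounds alone, the earlier compounds showed only that methyl reads lower than chloro here; the new step, a number 30.1 percentage points lower from compound 1 to compound 3 (beyond the scatter), shows the same for hydroxy, and with a number 26.7 percentage points lower from compound 1 to compound 2 (beyond the scatter) standing beside it, compound 1 is the highest of the three, with chloro the only group of the three that sets its compound apart in this assay. No measurement offered here explains why chloro stands apart from methyl and hydroxy at this position.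

From the compounds shown here alone, whether the higher number belongs to chloro alone or would also appear with fluoro, bromo or trifluoromethyl at this carbon remains open. Also open, going by these compounds, is how a methoxy group, an amine or a carboxylic acid would read there, and whether moving chloro to another carbon of the same ring would keep the number of compound 1.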